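Removing the butyl group from the pyrimidine ring of compound 3

The source may report more compounds than this note shows. Statements on the series, on what has been measured and on what is new or still open speak of the compounds shown alone.

Among the compounds with values here, in a functional assay on the whole organism for activation, with Mus musculus as the target (a lower number here means that less compound is needed, a higher number that more compound is needed for the effect), compound 3 `CCCCc1nc(N)c2nc(O)n(Cc3ccccc3)c2n1` gives 0.3 mg/kg and stands lowest of the three numbers so far. Its nearest neighbour is compound 2 `CCCNc1nc(N)c2nc(O)n(Cc3ccccc3)c2n1`, which gives 1 mg/kg; the furthest is compound 1 `Nc1ncnc2c1nc(O)n2Cc1ccc(F)cc1`, which gives 30 mg/kg. Within the data shown here, the one step that joins two measured compounds differing in a single place is a 3.3-fold lower number from compound 2 to compound 3 (0.52 log units; beyond the scatter), a change of one substituent for another on the same aromatic carbon.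

Compound 4 `Nc1ncnc2c1nc(O)n2Cc1ccccc1` is to be measured next. It differs from compound 3 as follows: hydrogen in place of butyl on an aromatic carbon. Among the measured compounds shown here, no measured step shows this exact change, since the step from compound 2 to compound 3 swaps one substituent for another rather than taking one away. What the data do show is that compound 1 also carries hydrogen at this carbon and differs from compound 4 only in the fluorine on its benzyl ring. In this assay compound 1 gives 30 mg/kg, far from compound 3 at 0.3 mg/kg. On that basis the step is expected to be a large rise in the number, a 33-fold higher number from compound 3 to compound 4 (1.52 log units; beyond the scatter). Compound 4 is therefore estimated to give 10 mg/kg, with a range from 2 mg/kg to 50 mg/kg.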

Compound 4, minimum effective dose: 30 mg/kg
Beside the measured number, compound 4's estimate is 3.0-fold (0.48 log units) below it; the range from low to high includes it.
By their numbers in this assay, from the lowest: compound 3; then compound 2; then compounds 1 and 4 (each within the scatter of the next).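

In this assay, a substituent on the aromatic carbon between two ring nitrogen atoms proves to matter in itself, and the earlier swap of one substituent for another could not show this: hydrogen in place of butyl gives a 100-fold higher number from compound 3 to compound 4 (2.00 log units; beyond the scatter), and hydrogen in place of propylamino gives a 30-fold higher number from compound 2 to compound 4 (1.48 log units; beyond the scatter). Next to these two removals, the exchange of propylamino for butyl, a 3.3-fold lower number from compound 2 to compound 3 (0.52 log units; beyond the scatter), is a small adjustment, so among the compounds shown, having either substituent at this carbon counts for more than which of the two it is. With hydrogen at this carbon, the change of fluoro to hydrogen on an aromatic carbon gives no change at the digits printed from compound 1 to compound 4 (within the scatter), so it does not register in this pair.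

Still open, on these data alone, is how a shorter chain such as methyl, a longer chain such as hexyl, or a carboxylic acid would compare at this carbon, and whether fluoro would stay without effect with butyl in place. Nothing at hand accounts for the size of these steps.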